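The source may hold more compounds than are shown below. What is called first, only, known or untested is meant among the compounds shown, and "the series" means these compounds.

Measured compounds in an assay for inhibition of prostacyclin synthase (Homo sapiens), using microsomes; a lower number here means a stronger inhibitor, a higher number a weaker inhibitor:
compound 1 `N#Cc1ccccc1C1OCC(C/C=C\CCC(=O)O)C(c2cccnc2)O1` gives > 100000 nM, which is a limit of the assay and not a number.
compound 2 `Cc1ccc(C#N)c(OC(C)(C)C2OCC(C/C=C\CCC(=O)O)C(c3cccnc3)O2)c1` gives > 100000 nM, likewise a limit of the assay and not a number.

Compound 2 thus stands only at a limit in this assay, with no number behind it, and compound 1 stands the same way, as the limit of > 100000 nM in this assay, at which 2 of the 2 values shown sit, shows. Going by the values given here, no step between measured compounds can be drawn from two limits, so nothing is known yet about what any change to the shared core does here.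

Compound 3 `COc1ccccc1OC(C)(C)C1OCC(C/C=C\CCC(=O)O)C(c2cccnc2)O1` is the next compound. Against compound 2 the change is 2-methoxyphenyl in place of 2-cyano-5-methylphenyl on an oxygen on a saturated carbon. Among the compounds with values here, with no measured step to lean on, the expected step in this assay is a number no higher from compound 2 to compound 3 (the limit leaves the size open), that is, none that can be told apart from the scatter. Compound 3 is accordingly expected at 100000 nM, with a range of 20000 nM to 500000 nM, and most probably the assay will again report only a limit.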

Compound 3, half-maximal inhibitory concentration: 51000 nM
For compound 3 the middle estimate is 2.0-fold (0.29 log units) above the measured one; measured number inside the range.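

In this assay, going by these compounds alone, compound 3 gives 51000 nM, the first actual number and a weak one. Compound 2 stands at > 100000 nM, which is a limit of the assay and not a number. On these data alone, with 2-methoxyphenyl in place of 2-cyano-5-methylphenyl on an oxygen on a saturated carbon, the result is an at least 1.9-fold lower number from compound 2 to compound 3 (0.29 log units; that floor lies within the scatter), so the true size of the step stays open and the change can be read only as one that brings the value into the measurable range.

As far as these compounds go, whether an amine or a carboxylic acid in place of the 2-methoxyphenyl would move the number further remains open. No step of known size can yet be read in this series, where most values still sit at the ceiling: the limit of > 100000 nM in this assay, at which 2 of the 3 values shown sit.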